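A Halogen Exchange on the Aryl Arm of Compound 2

A few compounds are considered here, and "the series" means these few. Any claim that something is new, unique, unknown or untested is made for them only; others in the source may bear on it.

Compound 1 `C=CCn1c(=O)/c(=C\c2cccc(Cl)c2)[nH]c(=O)/c1=C\c1ccccc1OC` and compound 2 `C=CCn1c(=O)/c(=C\c2cccc(F)c2)[nH]c(=O)/c1=C\c1ccccc1OC` share one core and differ only in the halogen carried by one phenyl group. In a functional assay on BGC-823 cells (Homo sapiens) for cytotoxicity, read by CCK-8 assay, with a stated time of 72 h (a lower number here means a stronger inhibitor, a higher number a weaker inhibitor), compound 1 gives 4600 nM and compound 2 gives 5600 nM. For the measured compounds named here, the single measured step is a 1.2-fold higher number from compound 1 to compound 2 (0.09 log units; within the scatter), so compound 2 holds the higher of the two numbers with compound 1 within the scatter of it, and no order between the two can be read from this.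

Compound 3 `C=CCn1c(=O)/c(=C\c2ccccc2Cl)[nH]c(=O)/c1=C\c1ccccc1OC` has not yet been measured. Relative to compound 2 the change is 2-chlorophenyl in place of 3-fluorophenyl on a double-bonded chain carbon bound to an aromatic carbon. Going by the values given here, the measured step bears on this only in part: it exchanged fluoro for chloro and stayed within the scatter, whereas the new step also alters the substitution pattern of the phenyl ring, for which no measured pair exists. Among the compounds with values here, with that single step as the only guide, no shift beyond the scatter is expected in this assay, but the range must stay wide. Compound 3 is therefore estimated to give 5000 nM, between 1800 nM and 14000 nM. The expected step is a 1.1-fold lower number from compound 2 to compound 3 (0.05 log units; within the scatter).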

Compound 3, half-maximal inhibitory concentration: 4600 nM
Estimate against measurement, compound 3: 1.1-fold (0.04 log units) above; the range from low to high includes it.
By their numbers in this assay, from the lowest: compounds 1, 3 and 2 (each within the scatter of the next).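

The new compound separates two things that the earlier pair could not. With chlorine held constant, in this assay the change to 2-chlorophenyl from 3-chlorophenyl on a double-bonded chain carbon bound to an aromatic carbon gives no change at the digits printed from compound 1 to compound 3 (within the scatter), so moving the halogen on this phenyl group leaves the number unchanged at the digits printed. The step that changes both the halogen and its ring position gives a 1.2-fold lower number from compound 2 to compound 3 (0.09 log units; within the scatter), so among these three compounds, neither the identity of the halogen nor its placement on this arm produces a shift beyond the scatter. No accompanying evidence is available to explain this result.

Going by these compounds, all three compounds carry a halogen on this phenyl group, so it remains open whether an amine or a carboxylic acid at the same place would shift the number beyond the scatter. The rest of the structure is also constant, which leaves open what a longer chain in place of the allyl group on the shared core would do in this assay.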